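The source may hold more compounds than are shown below. What is called first, only, known or untested is meant among the compounds shown, and "the series" means these compounds.

Measured compounds:
compound 1 `COc1cc(NC(=O)Nc2cc(Nc3cc(Br)ccc3OC)ncn2)cc(OC)c1`, 42.7%
compound 2 `COc1ccc(OC)c(Nc2cc(NC(=O)Nc3c(Cl)cccc3Cl)ncn2)c1`, 81.7%
compound 3 `CC(C)(C)c1ccc(Nc2cc(NC(=O)Nc3c(Cl)cccc3Cl)ncn2)cc1`, 40%

In a functional assay on NCI-H226 cells (Homo sapiens) for inhibition, read by MTT assay, with a stated time of 48 h, tested at 10 uM (on this read-out higher numbers stand for more inhibition at the one concentration tested (going by the name of the read-out) and lower numbers for less inhibition), compound 1 gives 42.7%. Among the three numbers it stands second highest; compound 3, at 40%, sits within the usual scatter of it, so the two cannot be told apart, while compound 2, at 81.7%, lies well beyond that scatter above it. Compound 4 `COc1cc(NC(=O)Nc2cc(Nc3cc(F)ccc3OC)ncn2)cc(OC)c1` has not yet been measured. It differs from compound 1 in one place: fluoro in place of bromo on an aromatic carbon. Within the data shown here, no pair of measured compounds shows this kind of swap, so its effect here is unknown. With only that to go on, compound 4 is expected to give 36% in this assay, between 15% and 60%. The step from compound 1 to compound 4 is thus estimated as a number 6.7 percentage points lower from compound 1 to compound 4 (within the scatter), a small change that may well stay within the scatter.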

Compound 4, a percentage reported as inhibition, at one concentration (the size of the read-out at that concentration, not a potency): 37.7%
Beside the measured number, compound 4's estimate is 1.7 percentage points below it; the measured number falls inside the stated range.
By their numbers in this assay, from the lowest: compounds 4, 3 and 1 (each within the scatter of the next); then compound 2.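

The swap of bromo for fluoro, on the aromatic carbon para to a methoxy group, gives a number 5 percentage points lower from compound 1 to compound 4 (within the scatter) in this assay. Among these compounds, this is the first measured view of this change, and it shows that on the core of compound 1 the two halogens cannot be told apart at this position. Nothing measured here bears on why they read alike. The compounds shown leave open whether an amine, a carboxylic acid or a longer chain such as propyl at this position would move the number beyond the scatter.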